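The source may report more compounds than this note shows. Statements on the series, on what has been measured and on what is new or still open speak of the compounds shown alone.

Of the compounds shown here, three sharing one core have been measured in a functional assay on MDA-MB-231 cells (Homo sapiens) for antiproliferative activity, read by MTT assay, with a stated time of 72 h; a higher number here means a weaker inhibitor, a lower number a stronger inhibitor. Compound 1 `O=C(CCc1cccc2c1B(O)OC2)Nc1cccc(I)c1`, carrying iodo, gives 5300 nM. Compound 2 `CC(C)c1cccc(NC(=O)CCc2cccc3c2B(O)OC3)c1`, carrying isopropyl, gives 1600 nM. Compound 3 `O=C(CCc1cccc2c1B(O)OC2)Nc1cccc(-c2cccc(Cl)c2)c1`, carrying 3-chlorophenyl, gives 250 nM, the lowest of the three numbers and so the strongest inhibitor of this small set.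

Compound 4 `COc1ccc(-c2cccc(NC(=O)CCc3cccc4c3B(O)OC4)c2)cc1` has not been measured. It differs from compound 3 in one place: 4-methoxyphenyl in place of 3-chlorophenyl on an aromatic carbon, with 4-methoxyphenyl in place of 3-chlorophenyl on an aromatic carbon.

The nearest evidence comes from two steps that end at the 3-chlorophenyl group: a 21-fold lower number from compound 1 to compound 3 (1.33 log units; beyond the scatter) and a 6.4-fold lower number from compound 2 to compound 3 (0.81 log units; beyond the scatter). Neither step swaps one substituted aromatic ring for another, whereas here both the leaving and the entering group hold one six-membered aromatic ring of carbon only. A gain as large as those two is therefore not expected in this assay, and neither is a loss of that size. At most a slight rise in the number is expected, with no step beyond the scatter. The estimated step is a 1.3-fold higher number from compound 3 to compound 4 (0.11 log units; within the scatter). Compound 4 is estimated at 320 nM, with an expected range of 110 nM to 900 nM.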

Compound 4, half-maximal inhibitory concentration: 88 nM
For compound 4 the middle estimate is 3.6-fold (0.56 log units) above the measured one, outside the stated range (below it).
By their numbers in this assay, from the lowest: compound 4; then compound 3; then compound 2; then compound 1.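

The earlier steps shown here only showed an aromatic ring replacing iodo or isopropyl, whereas this one shows that, in this assay, exchanging one substituted aromatic ring for another at this position still matters, with a 2.8-fold lower number from compound 3 to compound 4 (0.45 log units; beyond the scatter). The 4-methoxyphenyl group also extends the gains over the non-ring groups, with an 18-fold lower number from compound 2 to compound 4 (1.26 log units; beyond the scatter) and a 60-fold lower number from compound 1 to compound 4 (1.78 log units; beyond the scatter), making compound 4 the strongest inhibitor of the four. No measurement shown here explains why this exchange lowers the number.

The 3-chlorophenyl and 4-methoxyphenyl groups differ both in the atoms attached to the ring and in where those atoms sit, so the compounds shown cannot separate these two changes. On these data alone, it also remains open how a ring carrying an amine or a carboxylic acid would behave at this position.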